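Piperidin-1-yl in Place of Dipropylamino on a Sulfonyl Sulfur

The source may hold more compounds than are shown below. What is called first, only, known or untested is meant among the compounds shown, and "the series" means these compounds.

Three measured compounds share a common core and differ in the group attached to an aromatic carbon of that core. Compound 1 `CCN(CC)C(=O)c1ccc(NC(=O)C(C)(O)C(F)(F)F)cc1` carries a diethylcarbamoyl group; in an assay on a protein complex (Cavia porcellus) with sulfonylurea receptors; K-ATP channels (Homo sapiens) as the target (on this read-out higher numbers stand for weaker inhibition and lower numbers for stronger inhibition), compound 1 returns only a limit of the assay, > 30000 nM, not a number. Compound 3 `CC(O)(C(=O)Nc1ccc(Sc2ccccc2)cc1)C(F)(F)F` carries a phenylsulfanyl group, and compound 3 likewise returns only the limit > 30000 nM. The step that the two limits leave unreadable from compound 1 to compound 3 therefore cannot be read. Compound 2 `CCCN(CCC)S(=O)(=O)c1ccc(NC(=O)C(C)(O)C(F)(F)F)cc1` is the only one of the three with a measured number: in this assay compound 2 gives 6440 nM. The two other values sit at the limit of > 30000 nM in this assay, at which 2 of the 3 values shown sit.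

Compound 4 `CC(O)(C(=O)Nc1ccc(S(=O)(=O)N2CCCCC2)cc1)C(F)(F)F` differs from compound 2 at one place: piperidin-1-yl in place of dipropylamino on a sulfonyl sulfur. Within the data shown here, none of the measured steps touches the group on the sulfonyl sulfur, so no measured step bears on this change. The expected step of a 1.2-fold higher number from compound 2 to compound 4 (0.09 log units; within the scatter) is therefore estimated as one that may stay within the usual scatter, in no firm direction. For compound 4 the expected value is 8000 nM, ranging from 2500 nM to 25000 nM.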

Compound 4, half-maximal inhibitory concentration: 9250 nM
Compound 4: middle estimate off by 1.2-fold (0.06 log units), on the low side; the range from low to high includes it.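

In this assay, putting piperidin-1-yl in place of dipropylamino on the sulfonyl sulfur gives a 1.4-fold higher number from compound 2 to compound 4 (0.16 log units; within the scatter). Among these compounds, this is the first step that can be read, and it lies within the usual scatter, so on this evidence the open chains of dipropylamino and the six-membered ring of piperidin-1-yl cannot be told apart at this position. Compound 1 and compound 3 stay at a limit of the assay, not a number: the limit of > 30000 nM in this assay, at which 2 of the 4 values shown sit.

The step between those two compounds cannot be read. Also open, on these data alone, is whether another group on the sulfonyl sulfur, such as morpholin-4-yl, a simple unsubstituted amine or the longer chains of dibutylamino, would move the number beyond the scatter.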